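A few compounds are considered here, and "the series" means these few. Any claim that something is new, unique, unknown or untested is made for them only; others in the source may bear on it.

Compound 1, `O=C1NC(=O)/C(=C/c2ccc(OCc3csc(-c4ccccc4)n3)cc2)S1`: 21.7%
Compound 2, `O=C1NC(=O)/C(=C/c2ccc(OCCSc3nnc(Cc4ccccc4)[nH]3)cc2)S1`: 22.8%

In a functional assay on the whole organism (strain Wistar) with Rattus norvegicus as the target, with a stated time of 15 days, at a dose of 10 mg/kg by the oral route (a lower number here means a weaker effect, a higher number a stronger effect of the compound at the dose given), compound 2 gives 22.8%, and compound 1 gives 21.7%; the two values lie within the usual scatter of each other, so neither can be called the stronger. Within the data shown here, compound 3, `O=C1NC(=O)/C(=C/c2ccc(OCCSc3nnc(-c4ccc([N+](=O)[O-])cc4)[nH]3)cc2)S1`, differs from compound 2 in one place: 4-nitrophenyl in place of benzyl on an aromatic carbon No measured pair shows the effect of such a change, so a step no larger than the scatter is expected in this assay, in no particular direction. The estimated step from compound 2 to compound 3 is a number 0.2 percentage points higher from compound 2 to compound 3 (within the scatter). Compound 3 is therefore expected to give about 23%, in a range from 10% to 38%.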

Compound 3, a percentage reported as activity, at one dose (the size of the read-out at that dose, not a potency): 15.3%
Compound 3: the middle estimate sits 7.7 percentage points above what was measured, within the range that was stated.
By their numbers in this assay, from the lowest: compounds 3, 1 and 2 (each within the scatter of the next).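

On an aromatic carbon of the five-membered aromatic ring with 3 nitrogen, putting 4-nitrophenyl in place of benzyl gives, in this assay, a number 7.5 percentage points lower from compound 2 to compound 3 (within the scatter). Among these compounds, this is the first pair differing in one place, and it shows that this exchange, which brings in 2 hydrogen-bond acceptors, stays within the usual scatter of this read-out. Nothing measured here says what lies behind the step. Open, from the compounds shown here alone, is how a plain phenyl or a 4-aminophenyl on this same carbon would read, which would help separate the role of the nitro group from that of the benzyl carbon.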